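Chalcone series: 4-chlorophenyl returns in place of 2-hydroxyphenyl

The compounds below may be only part of what the source reports. "The series", "measured", "known", "first", "only" and "open" are said of these compounds alone.

Compound 3 `Cc1ccc(N2COc3ccc(C(=O)/C=C/c4ccccc4O)cc3C2)cc1` stands lowest of the three measured compounds in a functional assay on the whole organism (strain Wistar) for inhibition, with Rattus norvegicus as the target, read by paw edema, with a stated time of 3 h, at a dose of 20 mg/kg by the oral route (a lower number here means less inhibition, a higher number more inhibition at the dose given (going by the name of the read-out)), at 51%. Compound 1 `COc1ccc(N2COc3ccc(C(=O)/C=C/c4ccc(Cl)cc4)cc3C2)cc1` gives 67.4% and compound 2 `COc1ccc(/C=C/C(=O)c2ccc3c(c2)CN(c2ccc(C)cc2)CO3)cc1` gives 70.4%; those two numbers lie within the scatter of each other. Compound 4 `Cc1ccc(N2COc3ccc(C(=O)/C=C/c4ccc(Cl)cc4)cc3C2)cc1` differs from compound 3 in one place: 4-chlorophenyl in place of 2-hydroxyphenyl on a double-bonded chain carbon bound to a double-bonded chain carbon. Among the measured compounds shown here, the only step that bears on this change is a number 19.4 percentage points lower from compound 2 to compound 3 (beyond the scatter), so taking 2-hydroxyphenyl away again is expected to recover most of that loss. Compound 1 already carries 4-chlorophenyl on a double-bonded chain carbon bound to a double-bonded chain carbon, and its number sits close to that of compound 2. Compound 4 is therefore expected to give 68%, between 58% and 78%, an upward step of a number 17 percentage points higher from compound 3 to compound 4 (beyond the scatter) beyond the scatter.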

Compound 4, a percentage reported as inhibition, in the whole organism at one dose (the size of the read-out at that dose, not a potency): 63.4%
For compound 4 the middle estimate is 4.6 percentage points above the measured one, within the range that was stated.
By their numbers in this assay, from the lowest: compound 3; then compounds 4, 1 and 2 (each within the scatter of the next).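

In this assay, 4-chlorophenyl in place of 2-hydroxyphenyl gives a number 12.4 percentage points higher from compound 3 to compound 4 (beyond the scatter) and sets compound 3 apart from a second partner, after 4-methoxyphenyl in compound 2. Chloro in place of methoxy on an aromatic carbon gives a number 7 percentage points lower from compound 2 to compound 4 (within the scatter) and so does not separate those two groups at this dose. Methyl in place of methoxy on an aromatic carbon gives a number 4 percentage points lower from compound 1 to compound 4 (within the scatter) and likewise leaves that pair unseparated.

Going by these compounds, how an amine or a carboxylic acid on this phenyl ring would read remains open. Nothing measured here accounts for these steps.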